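The source may hold more compounds than are shown below. What is called first, only, known or untested is meant among the compounds shown, and "the series" means these compounds.

Compound 1 `Cc1cc(=O)n(-c2ccc(F)cc2)nc1C(=O)Nc1ccc(Oc2ncnc3ccsc23)c(F)c1` serves as the anchor of this small series. In a functional assay on HepG2 cells (Homo sapiens) for cytotoxicity, read by MTT assay, with a stated time of 72 h (on this read-out lower numbers stand for stronger inhibition and higher numbers for weaker inhibition), compound 1 gives 470 nM. Compound 2 `Cc1cc(=O)n(-c2ccc(F)c(F)c2)nc1C(=O)Nc1ccc(Oc2ncnc3ccsc23)c(F)c1` differs from compound 1 in a single place, (fluoro in place of hydrogen on an aromatic carbon), and in this assay compound 2 gives 6930 nM, so the step is a 15-fold higher number from compound 1 to compound 2 (1.17 log units; beyond the scatter). Compound 3 `Cc1cc(=O)n(-c2ccc(F)cc2)nc1C(=O)Nc1ccc(Oc2ncnc3sccc23)cc1` is built on a different core from compound 1; the difference between the two cores is not broken down here. In this assay compound 3 gives 6460 nM, a number that lies close to that of compound 2 and far from that of compound 1.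

Compound 4 `Cc1cc(=O)n(-c2ccc(F)c(F)c2)nc1C(=O)Nc1ccc(Oc2ncnc3sccc23)cc1` has not yet been measured. It stands to compound 3 exactly as compound 2 stands to compound 1: the change is fluoro in place of hydrogen on an aromatic carbon, and the place of the change reads the same word for word in both pairs, so this is the same change carried onto the second core. Among the measured compounds shown here, the only guide to its size is the earlier step, a 15-fold higher number from compound 1 to compound 2 (1.17 log units; beyond the scatter), and a single step on a different core is a thin basis, so a straight repeat is tempered a little.

Compound 4 is therefore expected to give about 45000 nM in this assay. The expected range for compound 4 runs from 12000 nM to 150000 nM. This estimate means a step of a 7.0-fold higher number from compound 3 to compound 4 (0.84 log units; beyond the scatter), resting on the starting point of compound 3 at 6460 nM and on the earlier step of a 15-fold higher number from compound 1 to compound 2 (1.17 log units; beyond the scatter).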

Compound 4, half-maximal inhibitory concentration: 16800 nM
Beside the measured number, compound 4's estimate is 2.7-fold (0.43 log units) above it, and the stated range covers the measured number.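

In this assay, the change from 4-fluorophenyl to 3,4-difluorophenyl, carried onto the second core, gives a 2.6-fold higher number from compound 3 to compound 4 (0.42 log units; beyond the scatter), so the number moves in the same direction on both cores, towards weaker inhibition. The size of the step, however, does not carry over from one core to the other: the same change on two cores in this assay, a 15-fold higher number (1.17 log units; beyond the scatter) from compound 1 to compound 2 and a 2.6-fold higher number (0.42 log units; beyond the scatter) from compound 3 to compound 4, 5.7-fold (0.75 log units) apart, beyond the scatter of two such steps These two pairs show that the direction repeated and that the size cannot be read across from one core to the other in this series, but they do not show which part of the difference between the two cores goes with the smaller step, why the steps differ, or whether the direction would hold on any further core.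

The compounds shown leave open whether a chloro, methyl or methoxy group in place of the added fluoro would shift the number in the same direction on either core, and whether the size of such a step would again differ between the two. They also leave open how either core would respond if the methyl group on the ring that carries the amide were exchanged for a longer chain or an amine.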